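This account rests on a few compounds, and the source may have more. Where it says the series, first, only, none or still open, it means among the compounds named here.

Working notes on the series, plasma protein binding.

Of the compounds shown here, three on the shared core have been measured in an ADME assay on a cell-free system (plasma, Homo sapiens) for protein binding. Compound 1 `COCc1nc2nc(C)cc(Nc3ccc(C(F)(F)F)cc3)n2n1` gives 75.6%, compound 2 `CSc1nc2nc(C)cc(Nc3ccc(C(F)(F)F)cc3)n2n1` gives 91.8%, and compound 3 `COCCc1nc2nc(C)cc(Nc3ccc(S(F)(F)(F)(F)F)cc3)n2n1` gives 87.7%. Among these three, compound 3 holds the second highest unbound fraction: its nearest neighbour is compound 2, from which it differs by a gap that stays within the scatter, and its furthest is compound 1, also within the scatter. For the measured compounds named here, the only step between single-point neighbours, a 3.0-fold lower unbound fraction from compound 1 to compound 2 (0.47 log units; beyond the scatter), concerns the substituent on the core and not the group on the six-membered ring, so no measured step bears directly on the change now considered.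

Compound 4 `COCCc1nc2nc(C)cc(Nc3ccc(C(F)(F)F)cc3)n2n1` differs from compound 3 in one place: a group of 4 heavy atoms (1 carbon, 3 fluorine; no ring) in place of a group of 6 heavy atoms (5 fluorine, 1 sulfur; no ring), on an aromatic carbon. Going by the values given here, nothing measured here compares these two groups head to head, and the pair compound 3 and compound 4 offers no precedent, so the expectation rests on the scatter alone and on compound 3 at 87.7%. For compound 4 the expected change is a 1.5-fold higher unbound fraction from compound 3 to compound 4 (0.19 log units; within the scatter), a step not expected to clear the scatter. Compound 4 is estimated at 81% in this assay, with a range from 66% to 91%.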

Compound 4, plasma protein binding: 73.7%
For compound 4 the middle estimate is 1.4-fold (0.14 log units) (unbound fraction) below the measured one; low and high end bracket the measured number.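

In this assay, the group on the aromatic carbon para to a large group now has a direct comparison: with 2-methoxyethyl held on the shared core, trifluoromethyl in place of the group of 6 heavy atoms (5 fluorine, 1 sulfur) gives a 2.1-fold higher unbound fraction from compound 3 to compound 4 (0.33 log units; beyond the scatter), so this position does register in the read-out, though only modestly. With trifluoromethyl held, the other side of the molecule also gains definition: 2-methoxyethyl in place of methylsulfanyl gives a 3.2-fold higher unbound fraction from compound 2 to compound 4 (0.51 log units; beyond the scatter), while the methoxymethyl and 2-methoxyethyl compounds are not separated, with a 1.1-fold higher unbound fraction from compound 1 to compound 4 (0.03 log units; within the scatter), so among these three compounds methylsulfanyl alone stands apart. No measurement on hand speaks to what lies behind either step.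

The trifluoromethyl swap is shown against one chain only, so it remains open whether the step is the same size with methylsulfanyl or methoxymethyl on the core. Also open, on these data alone, is how an amine or a carboxylic acid at the aromatic position, or a longer ether chain on the core, would read in this assay.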